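The source may report more compounds than this note shows. Statements on the series, on what has been measured and on what is new or still open speak of the compounds shown alone.

Three compounds that share one core and differ in a single group have been measured in an ADME assay on microsomes from liver (Rattus norvegicus) for metabolic stability, read by LC-MS, with a stated time of 10 min, tested at 0.5 uM; a higher number here means that more of the compound is left, a lower number that less of the compound is left. Compound 1 `c1cnc2c(c1)CCC[C@@H]2N(CCCN1CCNCC1)Cc1cc2ccccc2cn1` gives 59%, compound 2 `c1cnc2c(c1)CN[C@H](CN(CCCN1CCNCC1)[C@H]1CCCc3cccnc31)C2` gives 87%, and compound 3 `c1cnc2c(c1)CCC[C@@H]2N(CCCN1CCNCC1)Cc1nc2ccccc2s1` gives 21%, the lowest number of the three.

The next compound to be measured is compound 4 `c1cnc(CN(CCCN2CCNCC2)[C@H]2CCCc3cccnc32)nc1`, and the change that leads to it from compound 3 is this: pyrimidin-2-yl in place of 1,3-benzothiazol-2-yl on a saturated chain carbon bound to an amine nitrogen. In other words, pyrimidin-2-yl takes the place of 1,3-benzothiazol-2-yl on the same saturated chain carbon bound to an amine nitrogen.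

Among the compounds with values here, no measured compound carries pyrimidin-2-yl, so the evidence is indirect. Two measured steps arrive at the group that now leaves, and both are large: a number 38 percentage points lower from compound 1 to compound 3 (beyond the scatter), and a number 66 percentage points lower from compound 2 to compound 3 (beyond the scatter). The remaining step, a number 28 percentage points higher from compound 1 to compound 2 (beyond the scatter), is modest and shows that this place can also hold a group that gives a high number. Both other groups tested here give higher numbers than compound 3, so removing its group should raise the number, although how far is uncertain.

The expected change is a large rise, estimated as a number 47 percentage points higher from compound 3 to compound 4 (beyond the scatter). For compound 4 the estimated value is 68%, with an expected range from 42% to 90%.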

Compound 4, percent of the compound remaining: 68%
Compound 4: the middle estimate sits on the measured number at the digits printed; measured number inside the range.
By their numbers in this assay, from the lowest: compound 3; then compounds 1 and 4 (each within the scatter of the next); then compound 2.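

In this assay, the result shows that this place does not need two rings to escape the low number of compound 3: a single six-membered aromatic ring gives a number 47 percentage points higher from compound 3 to compound 4 (beyond the scatter), although the leaving and entering groups have equal counts of hydrogen-bond donors and acceptors. Pyrimidin-2-yl and isoquinolin-3-yl cannot be told apart here, with a number 9 percentage points higher from compound 1 to compound 4 (within the scatter), while a number 19 percentage points lower from compound 2 to compound 4 (beyond the scatter) leaves the group of compound 2 clearly on top. The number of heavy atoms in the group therefore does not set the order by itself, since compound 4 carries the smallest group and compound 3 the next smallest, yet compound 3 stays lowest and compound 4 matches compound 1, whose group is among the largest.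

A thiazol-2-yl group, which keeps the five-membered ring with its sulfur but lacks the six-membered carbon ring, could show which part of 1,3-benzothiazol-2-yl goes with the low number, and phenyl could show whether the ring nitrogens of pyrimidin-2-yl matter at all. Why these groups differ remains open, as no measurement shown here gives a reason for the differences.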